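A Hydroxyphenyl Swap Repeated on a Hydroxylated Core

A few compounds are considered here, and "the series" means these few. Any claim that something is new, unique, unknown or untested is made for them only; others in the source may bear on it.

Compound 1 `CC(C)=CCOc1ccc2c(c1)OC(c1ccc(C)cc1C)CC2=O` was tested in a functional assay (a higher number here means a weaker inhibitor, a lower number a stronger inhibitor), where compound 1 gives 8260 nM. Compound 2 `CC(C)=CCOc1ccc2c(c1)OC(c1ccc(O)cc1)CC2=O` carries 4-hydroxyphenyl in place of 2,4-dimethylphenyl on a saturated ring carbon and in this assay compound 2 gives 6670 nM, a step of a 1.2-fold lower number from compound 1 to compound 2 (0.09 log units; within the scatter). Compound 3 `CC(C)=CCOc1cc(O)c2c(c1)OC(c1ccc(C)cc1C)CC2=O` differs from compound 1 by hydroxy in place of hydrogen on an aromatic carbon, and in this assay compound 3 gives 6380 nM, a step of a 1.3-fold lower number from compound 1 to compound 3 (0.11 log units; within the scatter). Compound 4 `CC(C)=CCOc1cc(O)c2c(c1)OC(c1ccc(O)cc1)CC2=O` is not yet measured; it carries 4-hydroxyphenyl in place of 2,4-dimethylphenyl on a saturated ring carbon, the same change already seen in a 1.2-fold lower number from compound 1 to compound 2 (0.09 log units; within the scatter). Since that earlier step stayed within the scatter, the expected step is a 1.2-fold lower number from compound 3 to compound 4 (0.06 log units; within the scatter), resting on a 1.2-fold lower number from compound 1 to compound 2 (0.09 log units; within the scatter). Compound 4 is therefore expected to give about 5500 nM in this assay, estimated to fall between 2500 nM and 12000 nM.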

Compound 4, half-maximal inhibitory concentration: 5340 nM
For compound 4 the middle estimate is 1.0-fold (0.01 log units) above the measured one, within the range that was stated.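

On the hydroxylated core in this assay, 4-hydroxyphenyl in place of 2,4-dimethylphenyl gives a 1.2-fold lower number from compound 3 to compound 4 (0.08 log units; within the scatter), and this step agrees with the one on the core of compound 1: the same change on two cores in this assay, a 1.2-fold lower number (0.09 log units; within the scatter) from compound 1 to compound 2 and a 1.2-fold lower number (0.08 log units; within the scatter) from compound 3 to compound 4, 1.0-fold (0.02 log units) apart, within the scatter of two such steps. Hydroxy in place of hydrogen on an aromatic carbon gives a 1.2-fold lower number from compound 2 to compound 4 (0.10 log units; within the scatter), and this step also agrees with its earlier counterpart: the same change on two cores in this assay, a 1.3-fold lower number (0.11 log units; within the scatter) from compound 1 to compound 3 and a 1.2-fold lower number (0.10 log units; within the scatter) from compound 2 to compound 4, 1.0-fold (0.02 log units) apart, within the scatter of two such steps. Among these compounds, all of these steps lie within the scatter, so the agreement shows only that neither change moves the number beyond the scatter on either core in this assay; it does not show that a real effect carries from one core to another.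

On these data alone, it remains open whether an amine or a carboxylic acid in place of the hydroxy on the phenyl ring, or a longer chain on the ether oxygen, would give a step beyond the scatter. As far as these compounds go, it also remains open whether such a step would carry between these cores.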